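The source may hold more compounds than are shown below. What is called first, only, known or untested is meant among the compounds shown, and "the series" means these compounds.

Measured compounds:
- compound 1, `COc1cc(/C=C2\CCC/C(=C\c3ccccc3[N+](=O)[O-])C2=O)cc(Br)c1OC`: 3.35 ug/mL
- compound 2, `CCCOc1c(Br)cc(/C=C2\CCC/C(=C\c3ccccc3[N+](=O)[O-])C2=O)cc1OC`: 4.14 ug/mL
- compound 3, `CCCOc1c(Br)cc(/C=C2\CCC/C(=C\c3cccc([N+](=O)[O-])c3)C2=O)cc1OC`: 0.85 ug/mL

In a functional assay on MCF7 cells (Homo sapiens) for cytotoxicity, read by MTT assay (on this read-out higher numbers stand for weaker inhibition and lower numbers for stronger inhibition), compound 1 stands second highest of the three numbers. Its nearest neighbour is compound 2, with a 1.2-fold higher number from compound 1 to compound 2 (0.09 log units; within the scatter), a step that stays within the scatter, so the two cannot be told apart. The furthest is compound 3, whose number sits beyond the scatter below that of compound 1.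

The step to the unmeasured compound 4, `COc1cc(/C=C2\CCC/C(=C\c3ccc([N+](=O)[O-])cc3)C2=O)cc(Br)c1OC`, is 4-nitrophenyl in place of 2-nitrophenyl on a double-bonded chain carbon bound to a double-bonded ring carbon. Among the compounds with values here, no measured pair carries this exact change. Within the data shown here, the only step that touches the same position of the core is a 4.9-fold lower number from compound 2 to compound 3 (0.69 log units; beyond the scatter), where the nitro group was moved from one position of the pendant ring to another and the number fell by a modest amount. That step shows that relocating the nitro group on this ring can shift the number in this assay by more than the scatter, but it says nothing direct about the 4-nitrophenyl arrangement, so the direction for compound 4 is uncertain.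

On that basis a modest downward step is expected, a 2.1-fold lower number from compound 1 to compound 4 (0.32 log units; beyond the scatter), with wide bounds. Compound 4 is estimated at 1.6 ug/mL in this assay, within a range of 0.5 ug/mL to 4.5 ug/mL.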

Compound 4, half-maximal inhibitory concentration: 11 ug/mL
Compound 4: the middle estimate sits 6.9-fold (0.84 log units) below what was measured; measured number outside the range, above it.
By their numbers in this assay, from the lowest: compound 3; then compounds 1 and 2 (each within the scatter of the next); then compound 4.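

In this assay the nitro position on the pendant ring sets the direction of the change: 4-nitrophenyl in place of 2-nitrophenyl gives a 3.3-fold higher number from compound 1 to compound 4 (0.52 log units; beyond the scatter) and so moves the number upward, beyond the scatter. The earlier step with 3-nitrophenyl in place of 2-nitrophenyl, a 4.9-fold lower number from compound 2 to compound 3 (0.69 log units; beyond the scatter) at the same place, runs the other way, so the nitro position at this place can move the number up or down. The two steps start from compounds that differ only in the chain on the aromatic oxygen, and that difference, a 1.2-fold higher number from compound 1 to compound 2 (0.09 log units; within the scatter) on its own, stays within the scatter; nothing available here accounts for the opposite directions.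

The compounds shown leave open whether the 3-nitrophenyl and 4-nitrophenyl results would keep their opposite directions if both were carried on a single chain at that oxygen. They also leave open how an unsubstituted phenyl, or a phenyl carrying an amine or a carboxylic acid in place of the nitro group, would stand against these values at this place.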